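Ethynyl to fluoro exchange and kinetic solubility in the series

The compounds below may be only part of what the source reports. "The series", "measured", "known", "first", "only" and "open" are said of these compounds alone.

Measured compounds:
compound 1, `COc1ccccc1N1C(=O)CSC1c1cc(F)cc(C(=O)NCCCCc2ccccc2)c1`: 10000 nM
compound 2, `C#Cc1cc(C(=O)NCCCCc2ccccc2)cc(C2SCC(=O)N2c2ccccc2OC)c1`: 10000 nM
compound 3, `C#Cc1cccc(N2C(=O)CSC2c2cccc(C(=O)NCCCCc3ccccc3)c2)c1`: 10000 nM

In a physicochemical assay for solubility, read by turbidimetry, measured as kinetic solubility, at pH 7.4 (a higher number here means a more soluble compound, a lower number a less soluble compound), compound 1 gives 10000 nM, compound 2 gives 10000 nM and compound 3 gives 10000 nM; compound 3 stands level with compounds 1 and 2 in this assay, its values within the scatter of both. The change from compound 2 to compound 1 is fluoro in place of ethynyl on an aromatic carbon and it made the step of no change at the digits printed from compound 2 to compound 1 (within the scatter).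

Compound 4, `O=C(NCCCCc1ccccc1)c1cccc(C2SCC(=O)N2c2cccc(F)c2)c1`, is not yet measured. It differs from compound 3 by fluoro in place of ethynyl on an aromatic carbon. The difference between the core of compound 2 and the core of compound 3 is not broken down here. The two places are not the same word for word: in compound 2 the group sits meta to two large groups, in compound 3 meta to a large group, so the change to compound 4 is the same kind of change, not the same.

The step is expected to be no change at the digits printed from compound 3 to compound 4 (within the scatter), resting on the earlier step of no change at the digits printed from compound 2 to compound 1 (within the scatter) and on compound 3 giving 10000 nM, level with compounds 1 and 2. Compound 4 is estimated at 10000 nM in this assay, expected between 5000 nM and 20000 nM.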

Compound 4, solubility: 10000 nM
For compound 4 middle estimate and measured number coincide at the digits printed; measured number inside the range.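

In this assay, the exchange of ethynyl for fluoro reads the same on the two cores shown: no change at the digits printed from compound 2 to compound 1 (within the scatter) and no change at the digits printed from compound 3 to compound 4 (within the scatter). The two pairs therefore agree, although the exchanged group sits in a different place in each, but they show this only for these two cores and give no sign of how the exchange would read on any other core or in any other assay. Nothing available here bears on why the two pairs agree.

Still open, as far as these compounds go, is whether an amine or a carboxylic acid at the exchanged place, or a longer chain on the amide nitrogen, would give a step beyond the scatter in this assay. Also open is whether ethynyl and fluoro would read alike at other places on the aromatic rings, as the compounds shown hold the exchange at only two places.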